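Capping the amine: from compound 3 to compound 4

The source may hold more compounds than are shown below. What is called first, only, known or untested is meant among the compounds shown, and "the series" means these compounds.

Of the compounds shown here, three built on one shared core have been tested in an ADME assay on cells (Hepatocyte, Rattus norvegicus) for metabolic stability; on this read-out higher numbers stand for fast clearance and lower numbers for slow clearance. Within the data shown here, compound 1 `Cc1ccc2[nH]c(C(=O)N[C@H]3CN(S(=O)(=O)c4ccccc4)C[C@@H]3C(=O)N[C@H]3CCCNC3)cc2c1` gives 7 uL/min and compound 2 `O=C(N[C@H]1CN(S(=O)(=O)c2ccccc2)C[C@@H]1C(=O)N[C@H]1CCCNC1)c1cc(-c2ccc(Cl)cc2)on1` gives 2.22 uL/min; the one-point step between them, a 3.2-fold lower number from compound 1 to compound 2 (0.50 log units; beyond the scatter), is the only measured step in the set. Compound 3 `O=C(N[C@H]1CN(S(=O)(=O)c2ccccc2)C[C@@H]1C(=O)NC[C@@H]1CCCN1)c1cc(-c2ccccc2Cl)on1` gives 22 uL/min, the highest number of the three, so it is cleared fastest. Compound 4 `CC(=O)N1CCC[C@H](NC(=O)[C@H]2CN(S(=O)(=O)c3ccccc3)C[C@@H]2NC(=O)c2cc(-c3ccccc3Cl)on2)C1` differs from compound 3 at the amide-type nitrogen: 1-acetylpiperidin-3-yl in place of (pyrrolidin-2-yl)methyl on an amide-type nitrogen. Among the measured compounds shown here, no measured step touches this part of the molecule; the one known step concerns the group on the carbonyl carbon and was modest in size. For the measured compounds named here, the only guide is that compound 1 and compound 2, which carry a related ring at this position, both show lower numbers than compound 3. A modest downward change is expected, a 1.8-fold lower number from compound 3 to compound 4 (0.26 log units; within the scatter), though with little support. Compound 4 is therefore estimated at 12 uL/min, with a range from 4 uL/min to 35 uL/min.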

Compound 4, intrinsic clearance in a liver preparation (reported as CLH), per the amount of preparation that the assay uses in the Hepatocyte assay: 196 uL/min
Beside the measured number, compound 4's estimate is 16-fold (1.21 log units) below it; measured number above the stated range.
By their numbers in the Hepatocyte assay, from the lowest: compound 2; then compound 1; then compound 3; then compound 4.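

Among these compounds, replacing (pyrrolidin-2-yl)methyl with 1-acetylpiperidin-3-yl on an amide-type nitrogen gives the first measured step at this position: in the Hepatocyte assay there is an 8.9-fold higher number from compound 3 to compound 4 (0.95 log units; beyond the scatter), and the number moves upward, unlike the one earlier step, which went down at the carbonyl carbon. The same pair also separates in a second read-out: in a physicochemical assay for solubility, at pH 7.4 (a higher number here means a more soluble compound, a lower number a less soluble compound), compound 3 gives 503000 nM. In the physicochemical assay compound 4 gives < 500 nM, which is a limit of the assay and not a number, and the step from compound 3 therefore cannot be read as an exact size.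

The two groups differ in ring size and in the acetyl group at once, and the compounds shown do not separate these two parts. From the compounds shown here alone, whether a ring amine such as 1-methylpiperidin-3-yl at this position would sit nearer compound 3 or compound 4 stays open.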